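The compounds below may be only part of what the source reports. "The series", "measured", "known", "first", "only" and "open" are said of these compounds alone.

Of the compounds shown here, three built on one shared core have been tested in a functional assay on the whole organism (Hindlimb) for inhibition, with Mus musculus as the target, with a stated time of 4 h; a lower number here means that less compound is needed, a higher number that more compound is needed for the effect. Compound 1, `CC1(C)CC12NC(=O)N(NC(=O)c1ccc(Br)cc1)C2=O`, gives 300 mg/kg. Compound 2, `CC1(C)CC12NC(=O)N(NC(=O)c1ccc(F)cc1)C2=O`, gives 300 mg/kg, and compound 3, `CC1(C)CC12NC(=O)N(NC(=O)c1ccc([N+](=O)[O-])cc1)C2=O`, gives 300 mg/kg. The exchanges among them leave the read-out flat: no change at the digits printed from compound 1 to compound 2 (within the scatter), no change at the digits printed from compound 1 to compound 3 (within the scatter) and no change at the digits printed from compound 2 to compound 3 (within the scatter). Compound 3 therefore stands level with compounds 1 and 2 at the digits recorded, within the scatter of both.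

Compound 4, `CN(C)c1ccc(C(=O)NN2C(=O)NC3(CC3(C)C)C2=O)cc1`, brings a further change on an aromatic carbon of the same ring: dimethylamino in place of nitro on an aromatic carbon. All three measured steps bear on this change, since each swaps one group for another at an aromatic carbon of that ring, and none moved the read-out beyond the scatter. Going by the values given here, nothing measured so far points to a shift in this assay in either direction, so the expected step is no change at the digits printed from compound 3 to compound 4 (within the scatter), none beyond the scatter. For compound 4 the estimate in this assay is 300 mg/kg, with a range from 150 mg/kg to 600 mg/kg.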

Compound 4, minimum effective dose: 300 mg/kg
Compound 4: the middle estimate sits on the measured number at the digits printed; the range from low to high includes it.
By their numbers in this assay, from the lowest: compounds 1, 2, 3 and 4 (each within the scatter of the next).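

In this assay the new group fits the flat picture: no change at the digits printed from compound 3 to compound 4 (within the scatter), and likewise no change at the digits printed from compound 2 to compound 4 (within the scatter) and no change at the digits printed from compound 1 to compound 4 (within the scatter). This exchange differs in kind from the earlier ones, as a nitro group with its oxygens and a double bond outside aromatic rings gives way to dimethylamino, which carries carbons and a nitrogen, so para to a large group the four groups shown cannot be told apart even across this change of atoms. No other measurement is at hand to account for this flat read-out.

The compounds shown leave open whether any group at this place can move the read-out at all, for instance a carboxylic acid, a primary amine or a longer alkyl chain. They also leave open whether a change to the shared core itself would separate compounds that stand level here.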